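Moving a methyl from the sulfonamide nitrogen into the chain

The source may hold more compounds than are shown below. What is called first, only, known or untested is meant among the compounds shown, and "the series" means these compounds.

Measured compounds:
compound 1, `CNS(=O)(=O)Cc1noc2ccccc12`, 23 mg/kg
compound 2, `CCNS(=O)(=O)Cc1noc2ccccc12`, 39 mg/kg
compound 3, `CN(C)S(=O)(=O)Cc1noc2ccccc12`, 37 mg/kg

In a functional assay on the whole organism (strain STD-dd) with Mus musculus as the target, in the maximal electroshock model, with a stated time of 2 h (on this read-out higher numbers stand for an effect only at larger amounts of compound and lower numbers for an effect already at smaller amounts), compound 1 gives the lowest of the three numbers, though its steps to compound 2 and to compound 3 are both within the scatter. Compound 4, `NS(=O)(=O)CCc1noc2ccccc12`, differs from compound 1 by sulfamoylmethyl in place of methylsulfamoyl on a saturated chain carbon bound to an aromatic carbon. For the measured compounds named here, no measured step touches this rearrangement directly; the nearest are a 1.7-fold higher number from compound 1 to compound 2 (0.23 log units; within the scatter) and a 1.6-fold higher number from compound 1 to compound 3 (0.21 log units; within the scatter), which show that small changes at the sulfonamide nitrogen leave this assay almost unmoved. Compound 4 is therefore expected to stay close to compound 1, with a step of a 1.3-fold higher number from compound 1 to compound 4 (0.12 log units; within the scatter) in this assay. Compound 4 is estimated at 30 mg/kg, within 12 mg/kg to 75 mg/kg.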

Compound 4, dose for half-maximal effect: 26 mg/kg
Estimate against measurement, compound 4: 1.2-fold (0.06 log units) above, within the range that was stated.
By their numbers in this assay, from the lowest: compounds 1, 4, 3 and 2 (each within the scatter of the next).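

Exchanging methylsulfamoyl for sulfamoylmethyl on a saturated chain carbon bound to an aromatic carbon gives, in this assay, a 1.1-fold higher number from compound 1 to compound 4 (0.05 log units; within the scatter). The earlier compounds shown here changed only the groups on the sulfonamide nitrogen, whereas this pair shows that the same atoms can be joined differently, with the carbon moved from that nitrogen into the chain, and the step still stays within the scatter. Nothing available here gives a reason for this result. The compounds shown leave open whether an amine or a carboxylic acid in place of the sulfamoyl group, or a longer chain, would stay within the scatter of compound 1 in this assay.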